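This account rests on a few compounds, and the source may have more. Where it says the series, first, only, none or still open, it means among the compounds named here.

Measured compounds:
compound 1, `COc1cc(-c2nnc3n2NC(c2ccco2)C(C(=O)c2cccs2)S3)cc(OC)c1OC`, in a functional assay on HepG2 cells (Homo sapiens) for cytotoxicity, read by MTT assay, with a stated time of 48 h (a higher number here means a weaker inhibitor, a lower number a stronger inhibitor), compound 1 gives 64100 nM;
compound 3, `COc1cc(-c2nnc3n2NC(c2ccco2)C(C(=O)c2ccccc2C)S3)cc(OC)c1OC`, in this assay compound 3 gives 63000 nM;
compound 2, `COc1cc(-c2nnc3n2NC(c2ccco2)C(C(=O)c2ccc(C(F)(F)F)cc2)S3)cc(OC)c1OC`.

For compound 2 this assay gave no number, only a limit, > 100000 nM. That is the case set out by the limit of > 100000 nM in this assay, at which 1 of the 3 values shown sits.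

Compound 3 stands at the lower of the two full numbers, yet the gap a 1.0-fold lower number from compound 1 to compound 3 (0.01 log units; within the scatter) is within the scatter, so compound 1 and compound 3 stand level. The gap an at least 1.5-fold lower number from compound 2 to compound 3 (0.20 log units; that floor lies within the scatter) also rests on a floor within the scatter.

Compound 4, `COc1cccc(C(=O)C2Sc3nnc(-c4cc(OC)c(OC)c(OC)c4)n3NC2c2ccco2)c1`, has not yet been measured. It differs from compound 3 in one place: 3-methoxyphenyl in place of 2-methylphenyl on a carbonyl carbon. The two measured steps that bear on it both swap the aromatic group on the same carbonyl carbon, and neither moved the number beyond the scatter. On that basis the step of a 1.0-fold higher number from compound 3 to compound 4 (0.01 log units; within the scatter) is expected to show no change beyond the scatter. Compound 4 is therefore estimated at 65000 nM, within a range from 30000 nM to 140000 nM.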

Compound 4, half-maximal inhibitory concentration: > 100000 nM
Compound 4 gave a limit, no number; the forecaster's own chance of this, stated with the estimate: 25%; middle value at least 1.5-fold (0.18 log units) from the limit.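

In this assay compound 4 gives > 100000 nM, a limit and not a number. Set against the full numbers, this gives an at least 1.5-fold higher number from compound 3 to compound 4 (0.20 log units; that floor lies within the scatter) and an at least 1.5-fold higher number from compound 1 to compound 4 (0.19 log units; that floor lies within the scatter), so neither step shows a real change, and the step between compound 2 and compound 4 cannot be read, as both values are limits. What is new is that a second group on this carbonyl carbon, 3-methoxyphenyl alongside 4-(trifluoromethyl)phenyl, reaches the limit, while 2-methylphenyl in compound 3 and thiophen-2-yl in compound 1 still give full numbers: the limit of > 100000 nM in this assay, at which 2 of the 4 values shown sit.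

As far as these compounds go, whether compound 2 and compound 4 truly differ from compound 1 and compound 3 remains open. Also open, from the compounds shown here alone, is how an amine or a carboxylic acid on the aromatic group at this carbonyl carbon would read in this assay.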